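Phenyl for Isopropyl at the Indole Nitrogen Substituent

The compounds below may be only part of what the source reports. "The series", "measured", "known", "first", "only" and "open" are said of these compounds alone.

Measured so far:
- Compound 1, `CC(C)=CCn1ccc2cc(/C(C)=C/C(=O)Nc3ccccc3OCCCC(=O)O)ccc21`: 120 nM
- Compound 2, `CCCCC(CCCC)n1ccc2cc(/C(C)=C/C(=O)Nc3ccccc3OCCCC(=O)O)ccc21`: 21 nM
- Compound 3, `C/C(=C\C(=O)Nc1ccccc1OCCCC(=O)O)c1ccc2c(ccn2C(C(C)C)C(C)C)c1`: 14 nM

All three compounds share one core and differ only in the group carried on the aromatic nitrogen. In an assay on Prostate gland for inhibition of steroid 5-alpha-reductase (Rattus norvegicus) (a lower number here means a stronger inhibitor, a higher number a weaker inhibitor), compound 3 gives the lowest of the three numbers, yet its gap to compound 2 is within the scatter, so the two cannot be ranked; only compound 1 clearly stands apart, as an 8.6-fold lower number from compound 1 to compound 3 (0.93 log units; beyond the scatter) and a 5.7-fold lower number from compound 1 to compound 2 (0.76 log units; beyond the scatter) show. The step of a 1.5-fold lower number from compound 2 to compound 3 (0.18 log units; within the scatter) shows that exchanging one branched group for another changes little.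

Compound 4, `C/C(=C\C(=O)Nc1ccccc1OCCCC(=O)O)c1ccc2c(ccn2C(c2ccccc2)C(C)C)c1`, is not yet measured. It differs from compound 3 in one place: phenyl in place of isopropyl on a saturated chain carbon bound to an aromatic nitrogen and a saturated chain carbon. Going by the values given here, no measured step exchanges an alkyl group for an aromatic ring at this place, so there is no direct precedent. The two branched groups seen so far gave numbers close to each other, which suggests that the branching point itself matters more than what sits on it. The step from compound 3 to compound 4 is therefore expected to be small, a 1.1-fold higher number from compound 3 to compound 4 (0.06 log units; within the scatter), in no settled direction. Compound 4 is estimated at 16 nM, with a range from 5 nM to 50 nM.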

Compound 4, half-maximal inhibitory concentration: 25 nM
Estimate against measurement, compound 4: 1.6-fold (0.19 log units) below; the measured number falls inside the stated range.
By their numbers in this assay, from the lowest: compounds 3, 2 and 4 (each within the scatter of the next); then compound 1.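

On the saturated chain carbon bound to the aromatic nitrogen, an aromatic ring can replace an alkyl group in this assay without a readable change (a 1.8-fold higher number from compound 3 to compound 4 (0.25 log units; within the scatter)), even though phenyl brings 6 heavy atoms where isopropyl had 3. The 2-methyl-1-phenylpropyl group also cannot be separated from the long-armed 1-butylpentyl group (a 1.2-fold higher number from compound 2 to compound 4 (0.08 log units; within the scatter)), while it still stands clearly apart from the unbranched 3-methylbut-2-en-1-yl group (a 4.8-fold lower number from compound 1 to compound 4 (0.68 log units; beyond the scatter)), so among these four compounds, all three with two groups on that carbon sit together and only compound 1 stands apart. Nothing available explains why such different groups give such similar numbers.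

On these data alone, whether this tolerance extends to a phenyl ring carrying an amine or a carboxylic acid remains open. So does the outcome of placing a hydroxyl group on that carbon in place of the isopropyl.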